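The compounds below may be only part of what the source reports. "The series", "measured", "known", "first", "only" and "open" are said of these compounds alone.

Compound 2 `CN(C)CCNc1ccnc2cc(F)ccc12` is one of two analogues of the shared core measured in a functional assay on MCF7 cells (Homo sapiens) for cytotoxicity, read by sulforhodamine B assay, with a stated time of 48 h, in the presence of a further agent that is not named here; a lower number here means a stronger inhibitor of growth, a higher number a weaker inhibitor of growth. In this assay compound 2 gives 3260 nM, the lowest of the two numbers. Going by the values given here, its nearest neighbour is compound 1 `CN(C)CCNc1ccnc2cc(Cl)ccc12`, which in this assay gives 7370 nM; the only measured step between them, a 2.3-fold lower number from compound 1 to compound 2 (0.35 log units; beyond the scatter), is fluoro in place of chloro on an aromatic carbon. Compound 3 `COc1ccc2c(NCCN(C)C)ccnc2c1` has not yet been measured in this assay. It differs from compound 2 in one place: methoxy in place of fluoro on an aromatic carbon. Among the compounds with values here, no measured step shows a methoxy group entering or leaving the shared core, so the single measured step is only a loose guide: it shows that swapping one halogen for the other on this carbon moved the number by a modest amount, and a change to methoxy has no closer precedent. The expected step is therefore a 1.2-fold higher number from compound 2 to compound 3 (0.09 log units; within the scatter), with no firm direction claimed. Compound 3 is estimated at 4000 nM in this assay, with a range from 1500 nM to 12000 nM.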

Compound 3, concentration for 50% growth inhibition: 3660 nM
Compound 3: middle estimate off by 1.1-fold (0.04 log units), on the high side; the range from low to high includes it.
By their numbers in this assay, from the lowest: compounds 2, 3 and 1 (each within the scatter of the next, the first and the last beyond it).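

In this assay, going by these compounds alone, the change from fluoro to methoxy gives a 1.1-fold higher number from compound 2 to compound 3 (0.05 log units; within the scatter) and so cannot be told from no change, even though methoxy brings in a hydrogen-bond acceptor that fluoro lacks and is the first group on this aromatic carbon that is not a halogen. Measured against chloro, the same group gives a 2.0-fold lower number from compound 1 to compound 3 (0.30 log units; within the scatter) while the earlier step, a 2.3-fold lower number from compound 1 to compound 2 (0.35 log units; beyond the scatter), lay just beyond it, so compound 3 cannot be separated from either of the two halogen analogues, and the one step beyond the scatter among these three compounds remains the one from chloro to fluoro. Nothing measured here speaks to what lies behind these small differences.

On these data alone, whether a group of another kind on this carbon, such as an amine, a carboxylic acid or a longer alkoxy chain, would move the number well outside the span of these three compounds remains open. As far as these compounds go, the chain ending in the dimethylamine is the same in all three compounds, so what a change there would do to growth inhibition also remains open.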